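Working notes on three analogues sharing one core

The source may hold more compounds than are shown below. What is called first, only, known or untested is meant among the compounds shown, and "the series" means these compounds.

compound 1 `Cc1[nH]c2ccccc2c1-c1ccnc(NC(CO)C(C)C)n1` — 50000 nM
compound 2 `Cc1[nH]c2ccccc2c1-c1ccnc(N2CCN(c3ccc(F)cc3)CC2)n1` — > 100000 nM
compound 3 `Cc1[nH]c2ccccc2c1-c1ccnc(Nc2ccccc2Cl)n1` — not yet measured

In an assay on isolated protein for inhibition of interferon-induced, double-stranded RNA-activated protein kinase (Homo sapiens), read by luminescence, with a stated time of 10 min (on this read-out higher numbers stand for weaker inhibition and lower numbers for stronger inhibition), compound 1 gives 50000 nM. Compound 2 is reported in this assay only as > 100000 nM, which is a limit of the assay and not a number. The two values shown therefore already include (the limit of > 100000 nM in this assay, at which 1 of the 2 values shown sits). Going by the values given here, compound 1 is thus the only compound of the pair with a numerical value, and that value sits at the weak end of this assay; no step between measured compounds that differ in one place is available for comparison.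

Compound 3 differs from compound 1 in one place: 2-chlorophenyl in place of 1-(hydroxymethyl)-2-methylpropyl on a nitrogen on an aromatic ring. Among the compounds with values here, with no measured step to lean on, the expected step from compound 1 to compound 3 in this assay is a 1.7-fold lower number from compound 1 to compound 3 (0.22 log units; within the scatter), a change not clearly beyond the usual scatter of this assay. Compound 3 is accordingly estimated at 30000 nM, with an expected range from 5000 nM to 100000 nM.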

Compound 3, half-maximal inhibitory concentration: 19000 nM
Beside the measured number, compound 3's estimate is 1.6-fold (0.20 log units) above it, within the range that was stated.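

On a nitrogen on an aromatic ring, this assay now gives a first readable step, modest in size, with 2-chlorophenyl in place of 1-(hydroxymethyl)-2-methylpropyl: a 2.6-fold lower number from compound 1 to compound 3 (0.42 log units; beyond the scatter). The place therefore responds to a change of group, and an aromatic ring is accepted there without the number rising, even though the hydrogen-bond donor and acceptor of the group that leaves are absent from the group that enters. Nothing measured here bears on why the number falls.

Open, on these data alone, is whether the aromatic ring or the chlorine carries the step, which a plain phenyl on the same nitrogen would separate. Also open, as far as these compounds go, is what the hydroxymethyl contributes to compound 1, which a 2-methylpropyl chain without it would show.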